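Nitro to methoxy: from compound 2 to compound 4

The source may report more compounds than this note shows. Statements on the series, on what has been measured and on what is new or still open speak of the compounds shown alone.

Compound 2 `Cc1cnc(Nc2ccc([N+](=O)[O-])cc2)nc1Nc1nc2ccccc2s1` gives 6330 nM in a functional assay on HCT-116 cells (Homo sapiens) for antiproliferative activity, read by MTT assay, with a stated time of 48 h (a lower number here means a stronger inhibitor, a higher number a weaker inhibitor), the highest number among the three measured compounds. Compound 1 `Cc1cnc(Nc2ccc(S(C)(=O)=O)cc2)nc1Nc1nc2ccc(Cl)cc2s1` gives 2500 nM and compound 3 `Cc1cnc(Nc2ccc(S(N)(=O)=O)cc2)nc1Nc1nc2ccc(Cl)cc2s1` gives 2520 nM; the gap from each of these to compound 2 is beyond the scatter. Within the data shown here, the only measured single-point step, a 1.0-fold higher number from compound 1 to compound 3 (0.00 log units; within the scatter), concerns a sulfonyl group and does not touch the change considered here. Compound 4 `COc1ccc(Nc2ncc(C)c(Nc3nc4ccccc4s3)n2)cc1` differs from compound 2 by methoxy in place of nitro on an aromatic carbon. Among the measured compounds shown here, no measured pair shows a swap at this place, so there is no basis for expecting a shift beyond the scatter in this assay. The expected step is a 1.3-fold lower number from compound 2 to compound 4 (0.10 log units; within the scatter). Compound 4 is therefore estimated at 5000 nM, with a range of 1500 nM to 16000 nM.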

Compound 4, half-maximal inhibitory concentration: > 50000 nM
Compound 4 gave a limit, no number; the forecaster's own chance of this, stated with the estimate: 5%; middle value at least 10-fold (1.00 log units) away from the limit.
By their numbers in this assay, from the lowest: compounds 1 and 3 (each within the scatter of the next); then compound 2. At a limit, above all of these: compound 4.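

Among these compounds, the 4-nitrophenyl to 4-methoxyphenyl change gives the first measured swap at this position, and in this assay it is not neutral: an at least 7.8-fold higher number from compound 2 to compound 4 (0.89 log units; beyond the scatter). The group on this aromatic carbon can therefore, on its own, move the number beyond the scatter. Compound 4 gives a limit rather than a number, so the true size of the step remains unknown: the limit of > 50000 nM in this assay, at which 1 of the 4 values shown sits.

Open, from the compounds shown here alone, is how an amine or a carboxylic acid would read at this place. Also open, going by these compounds, is whether methoxy in place of a sulfonyl group would give a similar step on the core of compound 1.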